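A few compounds are considered here, and "the series" means these few. Any claim that something is new, unique, unknown or untested is made for them only; others in the source may bear on it.

Working notes on the series. Compound 1 `O=C(O)[C@@H]1CCCN1C(=O)CN(c1nc(Cl)nc2[nH]cnc12)C1CC1`, compound 2 `C[C@@H](O)[C@H](NC(=O)CN(c1nc(Cl)nc2[nH]cnc12)C1CC1)C(=O)OCc1ccccc1` and compound 3 `C[C@@H](O)[C@H](NC(=O)CN(c1nc(Cl)nc2[nH]cnc12)C1CC1)C(=O)O` share one core and have been run in a functional assay on the whole organism (Tail, strain ICR) with Mus musculus as the target, in the tail flick test, with a stated time of 30 min, at a dose of 25 umol/kg by the oral route; a higher number here means a stronger effect of the compound at the dose given, a lower number a weaker effect. In this assay compound 1 gives 31.5%, compound 2 gives 21.9% and compound 3 gives 18.6%. Compound 3 holds the lowest of the three numbers; its gap to compound 2 lies within the scatter, its gap to compound 1 beyond it. The step of a number 12.9 percentage points lower from compound 1 to compound 3 (beyond the scatter) goes with (1-carboxy-2-hydroxypropyl)amino in place of 2-carboxypyrrolidin-1-yl on a carbonyl carbon. The step of a number 3.3 percentage points lower from compound 2 to compound 3 (within the scatter), hydrogen in place of benzyl on an oxygen next to a carbonyl group, stays within the scatter.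

Compound 4 `NC(=O)CC[C@H](NC(=O)CN(c1nc(Cl)nc2[nH]cnc12)C1CC1)C(=O)O` is not yet measured. Against compound 3 the change is 2-carbamoylethyl in place of 1-hydroxyethyl on a saturated chain carbon bound to an amide-type nitrogen and a carbonyl carbon. Of the measured steps, only a number 12.9 percentage points lower from compound 1 to compound 3 (beyond the scatter) touches this part of the molecule, and it exchanged the whole amide-bearing fragment rather than one side chain for another; the step of a number 3.3 percentage points lower from compound 2 to compound 3 (within the scatter) altered a different end and was within the scatter. Among the measured compounds shown here, no measured step swaps one side chain alone. For compound 4 in this assay the expected step is a number 2.4 percentage points higher from compound 3 to compound 4 (within the scatter), nothing beyond the scatter. Compound 4 is estimated at 21%, between 8% and 34%.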

Compound 4, a percentage reported as activity, at one dose (the size of the read-out at that dose, not a potency): 33.1%
For compound 4 the middle estimate is 12.1 percentage points below the measured one, within the range that was stated.
By their numbers in this assay, from the lowest: compounds 3, 2, 1 and 4 (each within the scatter of the next, the first and the last beyond it).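

In this assay, among the compounds shown here, the side chain on a saturated chain carbon bound to an amide-type nitrogen and a carbonyl carbon can move the read-out on its own: 2-carbamoylethyl in place of 1-hydroxyethyl gives a number 14.5 percentage points higher from compound 3 to compound 4 (beyond the scatter), the only step that swaps one side chain alone. This changes how the earlier step of a number 12.9 percentage points lower from compound 1 to compound 3 (beyond the scatter) reads, since compound 4 at 33.1% and compound 1 at 31.5% stand within the scatter of each other, so losing the ring of 2-carboxypyrrolidin-1-yl does not by itself go with the lower number. The data at hand offer no explanation of why this side chain change goes with the higher number.

The compounds shown do not separate the carbamoyl end of 2-carbamoylethyl from the longer chain that carries it; a plain alkyl chain of the same length, or a carboxylic acid or an amine at its end, would bear on that. Going by these compounds, it also stays open whether a benzyl ester on compound 4 would stay within the scatter of the free acid, as a number 3.3 percentage points lower from compound 2 to compound 3 (within the scatter) does for the 1-hydroxyethyl side chain.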